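The source may hold more compounds than are shown below. What is called first, only, known or untested is meant among the compounds shown, and "the series" means these compounds.

Compound 1 `CSc1cc(C)nc(SC)c1NC(=O)N(Cc1ccccc1)Cc1cccc(-c2cc[nH]n2)c1`: 0.046 mg/kg
Compound 2 `O=C(Nc1c(F)cc(F)cc1F)N(Cc1ccccc1)Cc1cccc(-c2cc[nH]n2)c1`: 0.096 mg/kg

Within the data shown here, in a functional assay on the whole organism (plasma) with Rattus norvegicus as the target (a lower number here means that less compound is needed, a higher number that more compound is needed for the effect), compound 2 gives 0.096 mg/kg, the higher of the two numbers so far. Compound 3 `Cc1cc(C)c(NC(=O)N(Cc2ccccc2)Cc2cccc(-c3cc[nH]n3)c2)c(C)c1` places 2,4,6-trimethylphenyl where compound 2 has 2,4,6-trifluorophenyl: 2,4,6-trimethylphenyl in place of 2,4,6-trifluorophenyl on an amide-type nitrogen. Among the measured compounds shown here, one measured step bears on this change, a swap on the same amide-type nitrogen: a 2.1-fold higher number from compound 1 to compound 2 (0.32 log units; beyond the scatter). That step was modest, so no step beyond the scatter is expected here. The estimate means a 1.2-fold lower number from compound 2 to compound 3 (0.08 log units; within the scatter), an expected change that stays small. For compound 3 the expected value is 0.08 mg/kg, with an estimated range from 0.03 mg/kg to 0.22 mg/kg.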

Compound 3, dose for half-maximal effect: > 1 mg/kg
Compound 3: a limit, no number; the forecaster's own chance of this, stated with the estimate: 5%; middle value at least 12-fold (1.09 log units) away from the limit.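

Compound 3 gives a limit of the assay, not a number: the limit of > 1 mg/kg in this assay, at which 1 of the 3 values shown sits.

Both groups are six-membered aromatic rings of carbon only with equal heavy-atom counts, yet in this assay 2,4,6-trimethylphenyl in place of 2,4,6-trifluorophenyl gives an at least 10-fold higher number from compound 2 to compound 3 (1.01 log units; beyond the scatter). The step of an at least 21-fold higher number from compound 1 to compound 3 (1.33 log units; beyond the scatter) is also large, while the earlier swap on this nitrogen gave only a 2.1-fold higher number from compound 1 to compound 2 (0.32 log units; beyond the scatter), so this position does not accept every substituted aromatic ring equally.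

The compounds shown leave open whether 2,4,6-trichlorophenyl would behave like 2,4,6-trifluorophenyl or like 2,4,6-trimethylphenyl. They also do not tell how far compound 3 lies past its limit.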